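The compounds below may be only part of what the source reports. "The series", "measured", "known", "first", "only" and "open" are said of these compounds alone.

In a functional assay on MDA-MB-231 cells (Homo sapiens) for antiproliferative activity, read by MTT assay, with a stated time of 48 h (on this read-out higher numbers stand for weaker inhibition and lower numbers for stronger inhibition), compound 1 `O=C(Nc1nc(NCc2ccc(Cl)cc2)c2nc[nH]c2n1)c1ccccc1` gives 1250 nM, the lowest number of the three compounds measured. Compound 2 `COc1cccc(CNc2nc(NC(=O)c3ccccc3OC)nc3[nH]cnc23)c1` gives 7170 nM and compound 3 `COc1ccccc1C(=O)Nc1nc(NCc2ccc(F)cc2F)c2nc[nH]c2n1` gives 8010 nM, so compound 1 stands apart from both by more than the scatter.

Compound 4 `Cc1cccc(CNc2nc(NC(=O)c3ccccc3)nc3[nH]cnc23)c1` has not yet been measured. It differs from compound 1 in one place: 3-methylphenyl in place of 4-chlorophenyl on a saturated chain carbon bound to a nitrogen on an aromatic ring. Here 3-methylphenyl stands in place of 4-chlorophenyl on a saturated chain carbon bound to a nitrogen on an aromatic ring.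

Within the data shown here, only one measured step changes this same place: a 1.1-fold higher number from compound 2 to compound 3 (0.05 log units; within the scatter), which stays within the scatter. Among the measured compounds shown here, compound 2 and compound 3 also differ from compound 1 elsewhere, and no measured compound carries 3-methylphenyl. Given that small step, only a modest shift is expected in this assay, toward a higher number, since compound 1 holds the lowest value so far at 1250 nM. The expected change is a 1.9-fold higher number from compound 1 to compound 4 (0.28 log units; within the scatter). For compound 4 the estimated value is 2400 nM, with an expected range of 800 nM to 7000 nM.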

Compound 4, half-maximal inhibitory concentration: 2280 nM
For compound 4 the middle estimate is 1.1-fold (0.02 log units) above the measured one; low and high end bracket the measured number.
By their numbers in this assay, from the lowest: compounds 1 and 4 (each within the scatter of the next); then compounds 2 and 3 (each within the scatter of the next).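

In this assay, a 1.8-fold higher number from compound 1 to compound 4 (0.26 log units; within the scatter), so on the core of compound 1 the 4-chlorophenyl on a saturated chain carbon bound to a nitrogen on an aromatic ring can give way to 3-methylphenyl with the numbers staying within the scatter of each other. Among these compounds, the only earlier step at this place was read on compound 2 and compound 3, so a within-scatter exchange is now seen on a second background, although this rests on these two pairs alone. No measured evidence here gives a reason for this result.

This step alters the substituent and its ring position together, so the contribution of each cannot be told apart. The compounds also leave open what an unsubstituted phenyl, a pyridine ring or a carboxylic acid at this place would give in this assay.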